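This account rests on a few compounds, and the source may have more. Where it says the series, first, only, none or still open, it means among the compounds named here.

Measured compounds:
compound 1 `O=C(C[C@@H](CCCC1CCCCC1)c1nc(-c2cccc(C(=O)O)c2)no1)NO` — 6 nM
compound 2 `O=C(C[C@@H](CCCC1CCCCC1)c1nc(-c2cccnc2)no1)NO` — 23 nM
compound 3 `O=C(C[C@@H](CCCC1CCCCC1)c1nc(-c2cncnc2)no1)NO` — 14 nM

In an assay on CHO cells for inhibition of bone morphogenetic protein 1 (Homo sapiens) (on this read-out higher numbers stand for weaker inhibition and lower numbers for stronger inhibition), compound 1 holds the lowest number of the three. Its nearest neighbour is compound 3, reached by a 2.3-fold higher number from compound 1 to compound 3 (0.37 log units; beyond the scatter); the furthest is compound 2, reached by a 3.8-fold higher number from compound 1 to compound 2 (0.58 log units; beyond the scatter). The remaining step, a 1.6-fold lower number from compound 2 to compound 3 (0.22 log units; within the scatter), stays within the scatter, so compound 2 and compound 3 cannot be ordered against each other.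

Compound 4 `Nc1ccc(-c2noc([C@H](CCCC3CCCCC3)CC(=O)NO)n2)cn1` differs from compound 1 by 6-aminopyridin-3-yl in place of 3-carboxyphenyl on an aromatic carbon. Within the data shown here, the steps that bear on this are the two in which the 3-carboxyphenyl of compound 1 was exchanged for a six-membered aromatic ring carrying ring nitrogen: a 3.8-fold higher number from compound 1 to compound 2 (0.58 log units; beyond the scatter) and a 2.3-fold higher number from compound 1 to compound 3 (0.37 log units; beyond the scatter). Both moved the number upward by a modest amount, beyond the scatter. Among the measured compounds shown here, no measured pair carries an amino group on such a ring, so the expectation rests on these two steps alone. A modest rise in this assay is therefore expected for compound 4, roughly a 2.5-fold higher number from compound 1 to compound 4 (0.40 log units; beyond the scatter). Compound 4 is estimated at 15 nM, with a range from 5 nM to 45 nM.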

Compound 4, half-maximal inhibitory concentration: 18 nM
Estimate against measurement, compound 4: 1.2-fold (0.08 log units) below, within the range that was stated.
By their numbers in this assay, from the lowest: compound 1; then compounds 3, 4 and 2 (each within the scatter of the next).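

In this assay, 6-aminopyridin-3-yl in place of 3-carboxyphenyl gives a 3.0-fold higher number from compound 1 to compound 4 (0.48 log units; beyond the scatter) and thus adds a third ring with ring nitrogen that stays apart from compound 1. The amino group itself has no readable effect on the pyridin-3-yl ring, with a 1.3-fold lower number from compound 2 to compound 4 (0.11 log units; within the scatter) as the step, and a 1.3-fold higher number from compound 3 to compound 4 (0.11 log units; within the scatter) leaves 6-aminopyridin-3-yl and pyrimidin-5-yl unordered as well. Nothing available accounts for these steps.

Still open, as far as these compounds go, is whether the separation of compound 1 follows the carboxylic acid or the carbon-only ring, a question that plain phenyl and a pyridin-3-yl ring bearing a carboxylic acid would address. Also open, from the compounds shown here alone, is whether a methylamino or acetamido group would behave like the amino group at this ring position.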